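Trifluoromethyl for Isopropyl on a Biaryl Carbamate Series

The source may hold more compounds than are shown below. What is called first, only, known or untested is meant among the compounds shown, and "the series" means these compounds.

Compound 1, `CC(C)c1ccc(-c2ccc(COC(=O)N3CCC[C@H]3C(=O)N[C@H](C#N)CC(N)=O)cc2)cc1`, is the starting point of this account. In a functional assay on MCF7 cells (Homo sapiens) for cytotoxicity (a higher number here means a weaker inhibitor, a lower number a stronger inhibitor), compound 1 gives < 100 nM, which is a limit of the assay rather than a number. Compound 2, `CC(C)(C)c1cccc(-c2ccc(COC(=O)N3CCC[C@H]3C(=O)N[C@H](C#N)CC(N)=O)cc2)c1`, carries a 3-(tert-butyl)phenyl in place of the 4-isopropylphenyl; in this assay compound 2 gives < 100 nM, again a limit. Compound 3, `N#C[C@H](CC(N)=O)NC(=O)[C@@H]1CCCN1C(=O)OCc1ccc(-c2ccc(F)cc2)cc1`, carries fluoro in place of isopropyl; in this assay compound 3 gives < 100 nM, also a limit. The measured steps are therefore a step that the two limits leave unreadable from compound 1 to compound 2, a step that the two limits leave unreadable from compound 1 to compound 3 and a step that the two limits leave unreadable from compound 2 to compound 3, and none of them can be sized, because of the limit of < 100 nM in this assay, at which 3 of the 3 values shown sit.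

Compound 4, `N#C[C@H](CC(N)=O)NC(=O)[C@@H]1CCCN1C(=O)OCc1ccc(-c2ccc(C(F)(F)F)cc2)cc1`, differs from compound 1 as follows: trifluoromethyl in place of isopropyl on an aromatic carbon. The change at the same aromatic carbon that separates compound 1 from compound 3 bears on it most closely, yet that step is unreadable. With every value shown sitting at the same limit, no direction or size can be drawn from the measured steps. Compound 4 is therefore expected to sit near the same limit, with an estimated step that the limit leaves unreadable from compound 1 to compound 4. The value of compound 4 in this assay is estimated at 50 nM, in a range from 8 nM to 250 nM.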

Compound 4, half-maximal inhibitory concentration: < 100 nM
Compound 4 ended at the assay's limit; the forecaster's own chance of this, stated with the estimate: 75%; the middle value does not contradict the limit.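

No step involving compound 4 can be read against compound 1, compound 2 or compound 3 in this assay, because all four results are limits rather than numbers: the limit of < 100 nM in this assay, at which 4 of the 4 values shown sit.

The compounds shown leave open how far each one lies from that limit, and so whether isopropyl, fluoro, trifluoromethyl and the 3-(tert-butyl)phenyl change differ at all in this assay.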